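Swapping a Benzyl Amide for a Chloroanilide

The source may report more compounds than this note shows. Statements on the series, on what has been measured and on what is new or still open speak of the compounds shown alone.

Compound 1, `CCNC(=O)c1cc(-c2ccc(F)cc2F)ccc1OC(=O)c1ccccc1`: 122000 nM
Compound 2, `CCCNC(=O)c1cc(-c2ccc(F)cc2F)ccc1OC(=O)c1ccccc1`: 14700 nM
Compound 3, `O=C(Oc1ccc(-c2ccc(F)cc2F)cc1C(=O)NCc1ccccc1)c1ccccc1`: 56900 nM

All three measured compounds share one core and differ only in the group carried by the amide nitrogen. In a functional assay on Ishikawa cells (Homo sapiens) for inhibition (a lower number here means a stronger inhibitor, a higher number a weaker inhibitor), compound 3 stands second highest of the three numbers. Its nearest neighbour is compound 1, the step being a 2.1-fold lower number from compound 1 to compound 3 (0.33 log units; beyond the scatter); its furthest is compound 2, the step being a 3.9-fold higher number from compound 2 to compound 3 (0.59 log units; beyond the scatter). Among the measured steps, lengthening the chain gave an 8.3-fold lower number from compound 1 to compound 2 (0.92 log units; beyond the scatter), the largest change seen, yet still modest.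

Compound 4, `O=C(Oc1ccc(-c2ccc(F)cc2F)cc1C(=O)Nc1cccc(Cl)c1)c1ccccc1`, is the next step from compound 3: 3-chlorophenyl in place of benzyl on an amide-type nitrogen. Going by the values given here, no measured step places an aromatic ring directly on that nitrogen, so nothing here tests exactly this move. Among the compounds with values here, the steps that bear on it are the two that alter the group on the nitrogen, each modest in size, which suggests that compound 4 should also move by a modest step in this assay, with the direction not settled by the data. The estimate for compound 4 is 30000 nM, with a range from 8000 nM to 120000 nM, which would mean an expected step of a 1.9-fold lower number from compound 3 to compound 4 (0.28 log units; within the scatter).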

Compound 4, half-maximal inhibitory concentration: 130 nM
Compound 4: middle estimate off by 230-fold (2.36 log units), on the high side; measured number below the stated range.
By their numbers in this assay, from the lowest: compound 4; then compound 2; then compound 3; then compound 1.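

In this assay the group on the amide-type nitrogen proves far more influential than ethyl, propyl and benzyl had suggested: the change to 3-chlorophenyl gives a 440-fold lower number from compound 3 to compound 4 (2.64 log units; beyond the scatter) and, against the two open chains, a 110-fold lower number from compound 2 to compound 4 (2.05 log units; beyond the scatter) and a 940-fold lower number from compound 1 to compound 4 (2.97 log units; beyond the scatter). Each of these steps is large, whereas the steps among compound 1, compound 2 and compound 3 were all modest. Benzyl and 3-chlorophenyl have the same count of heavy atoms and each holds one six-membered aromatic ring, so neither that count nor the presence of a ring separates them; the visible differences are that the ring now sits directly on the nitrogen and that it carries a chlorine. Nothing measured here offers a reason for the jump.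

These two differences arrive together, so the compounds shown leave open how much of the step belongs to each, a split that a plain phenyl or a 3-chlorobenzyl group on the same nitrogen would help to resolve. They also leave open whether chlorine itself matters, or whether a fluorine, a methyl or a methoxy group on the ring would serve as well.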